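Cytotoxicity on the shared core: dihydroxyphenyl hydrazone

The source may hold more compounds than are shown below. What is called first, only, known or untested is meant among the compounds shown, and "the series" means these compounds.

Measured compounds:
- compound 1 `COc1ccccc1-c1nnc(-c2ccc(C(=O)N/N=C/c3cccc(O)c3)cc2)o1`: 398000 nM
- compound 2 `COc1ccccc1-c1nnc(-c2ccc(C(=O)N/N=C/c3cccc(F)c3)cc2)o1`: 353000 nM
- compound 3 `COc1ccccc1-c1nnc(-c2ccc(C(=O)N/N=C/c3ccc(Cl)cc3Cl)cc2)o1`: 78800 nM

In an ADME assay on THP-1 cells (Homo sapiens) for cytotoxicity (on this read-out higher numbers stand for weaker inhibition and lower numbers for stronger inhibition), compound 3 gives the lowest number of the three. The steps of a 5.1-fold lower number from compound 1 to compound 3 (0.70 log units; beyond the scatter) and a 4.5-fold lower number from compound 2 to compound 3 (0.65 log units; beyond the scatter) both lie beyond the scatter, whereas a 1.1-fold lower number from compound 1 to compound 2 (0.05 log units; within the scatter) lies within it, so compound 1 and compound 2 are not ordered against each other.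

Compound 4 `COc1ccccc1-c1nnc(-c2ccc(C(=O)N/N=C/c3cccc(O)c3O)cc2)o1` is not yet measured. It differs from compound 3 in one place: 2,3-dihydroxyphenyl in place of 2,4-dichlorophenyl on a carbon with a double bond to nitrogen. Going by the values given here, the nearest precedent is the reverse of the move from a hydroxy-bearing ring to the dichlorophenyl, seen as a 5.1-fold lower number from compound 1 to compound 3 (0.70 log units; beyond the scatter) and a 4.5-fold lower number from compound 2 to compound 3 (0.65 log units; beyond the scatter); no measured step covers the second hydroxy group. On that basis the number for compound 4 is expected to move back up towards that of compound 1, a step of about a 4.4-fold higher number from compound 3 to compound 4 (0.65 log units; beyond the scatter) in this assay. Compound 4 is estimated at 350000 nM, with a range from 120000 nM to 900000 nM.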

Compound 4, half-maximal inhibitory concentration: 102000 nM
Estimate against measurement, compound 4: 3.4-fold (0.54 log units) above; measured number outside the range, below it.
By their numbers in this assay, from the lowest: compounds 3 and 4 (each within the scatter of the next); then compounds 2 and 1 (each within the scatter of the next).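

In this assay, hydroxy in place of hydrogen on an aromatic carbon gives a 3.9-fold lower number from compound 1 to compound 4 (0.59 log units; beyond the scatter) and thus shows that a second hydroxy group on this ring changes the read-out, which the single hydroxy and fluoro rings did not show. The 2,3-dihydroxyphenyl ring also separates from the 3-fluorophenyl ring, with a 3.5-fold lower number from compound 2 to compound 4 (0.54 log units; beyond the scatter) beyond the scatter, whereas a 1.3-fold higher number from compound 3 to compound 4 (0.11 log units; within the scatter) lies within it, so a ring with 2 hydrogen-bond donors and one with none are not ordered against each other here. Nothing at hand accounts for the second hydroxy group and the two chlorines arriving at a similar level.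

Open, on these data alone, is how a single chlorine, a methoxy group, an amine or a carboxylic acid on this ring would read. Also open, as far as these compounds go, is whether any group on this ring reaches a number clearly lower than those of compound 3 and compound 4.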